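The source may report more compounds than this note shows. Statements on the series, on what has been measured and on what is new or still open speak of the compounds shown alone.

Measured compounds in a functional assay on NCI-H1581 cells (Homo sapiens) for inhibition, read by MTT assay, with a stated time of 48 h, tested at 10 uM; on this read-out higher numbers stand for more inhibition at the one concentration tested (going by the name of the read-out) and lower numbers for less inhibition:
- compound 1, `COc1cc(NC(=O)Nc2cc(Nc3cc(Br)ccc3OC)ncn2)cc(OC)c1`, gives 23.1%
- compound 2, `COc1ccc(OC)c(Nc2cc(NC(=O)Nc3c(Cl)cccc3Cl)ncn2)c1`, gives 93.1%
- compound 3, `CC(C)(C)c1ccc(Nc2cc(NC(=O)Nc3c(Cl)cccc3Cl)ncn2)cc1`, gives 71.3%

Of these three, compound 1 stands lowest in this assay. Its nearest neighbour is compound 3, whose number is higher by a gap beyond the usual scatter, and compound 2 lies higher still, also beyond the scatter. The inhibition of compound 1 in this assay is thus the lowest of the three.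

Compound 4, `COc1cc(NC(=O)Nc2cc(Nc3cc(F)ccc3OC)ncn2)cc(OC)c1`, has not yet been measured. It differs from compound 1 in one place: fluoro in place of bromo on an aromatic carbon. The rest of the molecule, including the shared core and the dimethoxyphenyl urea, is unchanged.

Among the measured compounds shown here, no measured pair differs by just this exchange, so there is no directly comparable step to lean on. One halogen gives way to another of the same kind of size class, and nothing in the three measured numbers suggests that this exchange alone should move the read-out far. The expected step from compound 1 to compound 4 is therefore small, a number 3.1 percentage points lower from compound 1 to compound 4 (within the scatter), not clearly beyond the scatter in either direction. For compound 4 in this assay the estimate is 20%, with a likely range from 5% to 45%.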

Compound 4, a percentage reported as inhibition, at one concentration (the size of the read-out at that concentration, not a potency): 42.1%
Compound 4: the middle estimate sits 22.1 percentage points below what was measured, and the stated range covers the measured number.
By their numbers in this assay, from the lowest: compound 1; then compound 4; then compound 3; then compound 2.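

In this assay the exchange of bromo for fluoro, at the aromatic carbon para to a methoxy group, gives a number 19 percentage points higher from compound 1 to compound 4 (beyond the scatter). Among the compounds shown here, this is the first pair that differs in one place only, and it shows that this position is not indifferent to which halogen it carries: a change of a single atom is enough to move the read-out beyond the usual scatter. The data offer no measurement that accounts for this step.

As far as these compounds go, with only these two groups compared at this carbon, it remains open whether the read-out would follow any trend with other groups, such as a nitrile or an amine. From the compounds shown here alone, it is also open whether the same exchange would give a similar step with a different group on the urea.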